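The source may hold more compounds than are shown below. What is called first, only, known or untested is meant among the compounds shown, and "the series" means these compounds.

Compound 1 `Cc1nc(S(C)(=O)=O)ccc1Oc1ncnc(OC2CCN(C(=O)O[C@@H](C)CF)CC2)c1F`: 1680 nM
Compound 2 `Cc1nc(S(C)(=O)=O)ccc1Oc1ncnc(OC2CCN(C(=O)O[C@H](C)C(F)(F)F)CC2)c1F`: 110 nM
Compound 3 `CCC1(OC(=O)N2CCC(Oc3ncnc(Oc4ccc(S(C)(=O)=O)nc4C)c3F)CC2)CC1`: 333 nM

In a functional assay on isolated protein for inhibition of Glucose-dependent insulinotropic receptor (Rattus norvegicus), read by HTRF and cAMP accumulation (a higher number here means that more compound is needed for the effect, a lower number that less compound is needed), compound 3 gives 333 nM, the second highest of the three numbers: compound 2 sits a 3.0-fold higher number from compound 2 to compound 3 (0.48 log units; beyond the scatter) away, compound 1 further, at a 5.0-fold lower number from compound 1 to compound 3 (0.70 log units; beyond the scatter). Compound 4 `Cc1nc(S(C)(=O)=O)ccc1Oc1ncnc(OC2CCN(C(=O)SC3CCC3)CC2)c1F` differs from compound 3 by a group of 5 heavy atoms (4 carbon, 1 sulfur; one four-membered non-aromatic ring of carbon only) in place of a group of 6 heavy atoms (5 carbon, 1 oxygen; one three-membered non-aromatic ring of carbon only), on a carbonyl carbon. The measured steps all vary the group on that carbonyl, and their sizes span a 15-fold lower number from compound 1 to compound 2 (1.18 log units; beyond the scatter), a 5.0-fold lower number from compound 1 to compound 3 (0.70 log units; beyond the scatter) and a 3.0-fold higher number from compound 2 to compound 3 (0.48 log units; beyond the scatter). Among the measured compounds shown here, none of them replaces the oxygen by sulfur, so the new group has no direct precedent. A step of modest size in either direction is therefore expected for compound 4 in this assay, with no firm direction, giving an estimated 350 nM (range 90 nM to 1400 nM), which means an expected 1.1-fold higher number from compound 3 to compound 4 (0.02 log units; within the scatter).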

Compound 4, half-maximal effective concentration: 77.4 nM
The estimate for compound 4 lay 4.5-fold (0.66 log units) above the measured number, outside the stated range (below it).
By their numbers in this assay, from the lowest: compounds 4 and 2 (each within the scatter of the next); then compound 3; then compound 1.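

In this assay a sulfur-linked group on this carbonyl carbon proves compatible with low numbers, as cyclobutylsulfanyl gives a 4.3-fold lower number from compound 3 to compound 4 (0.63 log units; beyond the scatter) and a 22-fold lower number from compound 1 to compound 4 (1.34 log units; beyond the scatter) in the second comparison. Set against 1-(trifluoromethyl)ethoxy, it gives a 1.4-fold lower number from compound 2 to compound 4 (0.15 log units; within the scatter) and thus no order between the two groups. The sulfur and the ring size change together in compound 4, so the compounds shown cannot separate them, whereas cyclobutoxy or cyclobutylamino on the same carbonyl could. The reason for the result also stays open, and no measurement shown bears on it.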